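This account rests on a few compounds, and the source may have more. Where it says the series, first, only, none or still open, it means among the compounds named here.

Measured compounds:
Compound 1 `Cc1cccc(-n2nncc2CN2C(=O)C3(C(C#N)=C(N)Oc4c3c3nc5ccccc5nc3c3ccccc43)c3ccccc32)c1` gives 39600 nM in a functional assay on A549 cells (Homo sapiens) for antiproliferative activity, read by MTT assay, with a stated time of 48 h; on this read-out higher numbers stand for weaker inhibition and lower numbers for stronger inhibition.
Compound 2 `N#CC1=C(N)Oc2c(c3nc4ccccc4nc3c3ccccc23)C12C(=O)N(Cc1cnnn1-c1ccccc1Cl)c1ccccc12` gives 42600 nM.
Compound 3 `N#CC1=C(N)Oc2c(c3nc4ccccc4nc3c3ccccc23)C12C(=O)N(Cc1cnnn1-c1ccccc1Br)c1ccccc12` gives only a limit, > 50000 nM, with no number reported.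

Of the two numbers shown, compound 1 is separated from compound 2 only by a 1.1-fold higher number from compound 1 to compound 2 (0.03 log units; within the scatter), which lies within the scatter, so neither stands apart from the other. The step of an at least 1.2-fold higher number from compound 1 to compound 3 (0.10 log units; that floor lies within the scatter) runs up to the limit of > 50000 nM in this assay, at which 1 of the 3 values shown sits, and its floor also lies within the scatter.

Compound 4 `N#CC1=C(N)Oc2c(c3nc4ccccc4nc3c3ccccc23)C12C(=O)N(Cc1cnnn1-c1ccc(S(N)(=O)=O)cc1)c1ccccc12` differs from compound 1 in one place: 4-sulfamoylphenyl in place of 3-methylphenyl on an aromatic nitrogen. Among the measured compounds shown here, the steps that bear on this change are the two in which the group on that same aromatic nitrogen was exchanged, a 1.1-fold higher number from compound 1 to compound 2 (0.03 log units; within the scatter) and an at least 1.2-fold higher number from compound 1 to compound 3 (0.10 log units; that floor lies within the scatter); neither moved the number beyond the scatter, and an at least 1.1-fold higher number from compound 2 to compound 3 (0.06 log units; that floor lies within the scatter) likewise stayed within it. The exchanges of the aryl group seen so far have not shifted the read-out in this assay, so the expected step for compound 4 is none beyond the scatter, if anything toward a higher number, with a real chance that only a limit is reported. Compound 4 is therefore estimated at 45000 nM, in a range from 20000 nM to 100000 nM, which would be an expected step of a 1.1-fold higher number from compound 1 to compound 4 (0.06 log units; within the scatter).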

Compound 4, half-maximal inhibitory concentration: > 50000 nM
Compound 4: a limit, no number (the forecaster's own chance of this, stated with the estimate: 40%); at least 1.1-fold (0.04 log units) between middle value and limit.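

Until now the groups on this aromatic nitrogen were 3-methylphenyl, 2-chlorophenyl and 2-bromophenyl, none with a hydrogen-bond donor or acceptor; 4-sulfamoylphenyl brings both, and in this assay it still gives no sign of stronger inhibition, with an at least 1.2-fold higher number from compound 1 to compound 4 (0.10 log units; that floor lies within the scatter) and an at least 1.1-fold higher number from compound 2 to compound 4 (0.06 log units; that floor lies within the scatter). Compound 3 and compound 4 both end in limits, and the step between them cannot be read. So a much larger and differently built aryl group leaves the picture unchanged, and compound 4 joins compound 3 at a limit of the assay and not a number: the limit of > 50000 nM in this assay, at which 2 of the 4 values shown sit.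

From the compounds shown here alone, what an amine or a carboxylic acid on this phenyl ring, or a plain alkyl chain in place of the ring, would do to the number stays open. All four compounds shown carry a substituted phenyl ring at this position, so whether any group here can move the read-out beyond the scatter also remains unanswered.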